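Replacing a Chain Dimethylamino Group with Methyl

This account rests on a few compounds, and the source may have more. Where it says the series, first, only, none or still open, it means among the compounds named here.

Compound 1 `CN(C)CCCNc1nc(NCc2ccco2)c2ccccc2n1` carries a dimethylamino group on its chain, but in a functional assay on HCT-116 cells (Homo sapiens) for cytotoxicity, read by MTT assay, with a stated time of 2 days (on this read-out lower numbers stand for stronger inhibition and higher numbers for weaker inhibition), compound 1 is recorded as "not determined" (no result reported). Two related compounds on the same core were measured: compound 2 `Clc1cccc(N2CCN(CCCCNc3nc(NCc4ccco4)c4ccccc4n3)CC2)c1Cl` gives 3200 nM in this assay, and compound 3 `Cc1cccc(N2CCN(CCCNc3nc(NCc4ccco4)c4ccccc4n3)CC2)c1C` gives 770 nM. The step from compound 1 to compound 4 `CCCCNc1nc(NCc2ccco2)c2ccccc2n1` is methyl in place of dimethylamino on a saturated chain carbon, three bonds along the chain from a nitrogen on an aromatic ring. Within the data shown here, no measured pair shows this step, so its size is unknown; the author expects it to point toward weaker inhibition, possibly beyond the scatter, since compound 4 keeps none of the chain nitrogen present in compound 2 or compound 3. For compound 4 in this assay the estimated value is 10000 nM, with a range from 2000 nM to 50000 nM.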

Compound 4, half-maximal inhibitory concentration: 5470 nM
Compound 4: middle estimate off by 1.8-fold (0.26 log units), on the high side; measured number inside the range.
By their numbers in this assay, from the lowest: compound 3; then compounds 2 and 4 (each within the scatter of the next).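

Compound 1 has no number to set against compound 4, so no step can be read between them. The compounds shown leave open how far methyl in place of dimethylamino shifts inhibition on this chain. No evidence bears on this result.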